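Phenyl for isobutyl on the aryl ring of compound 1

The source may hold more compounds than are shown below. What is called first, only, known or untested is meant among the compounds shown, and "the series" means these compounds.

Measured so far:
Compound 1, `Cc1[nH]c(=O)n(C)c1-c1ccc(CC(C)C)cc1`: 30 mg/kg
Compound 2, `CCCCCCCCCCOc1ccc(-c2c(C)[nH]c(=O)n2C)cc1`: 0.1 mg/kg

The read-out is a functional assay on the whole organism with Rattus norvegicus as the target; on this read-out higher numbers stand for an effect only at larger amounts of compound and lower numbers for an effect already at smaller amounts. On this read-out compound 1 gives 30 mg/kg, the highest of the two numbers shown. Compound 2 gives 0.1 mg/kg in this assay, a number far below that of compound 1 and beyond the scatter. Among the measured compounds shown here, no pair differing in a single place has been measured, so no computed step is available; the two values only show that the aryl substituent in this position can move the minimum effective dose widely.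

Compound 3, `Cc1[nH]c(=O)n(C)c1-c1ccc(-c2ccccc2)cc1`, is not yet measured. It differs from compound 1 as follows: phenyl in place of isobutyl on an aromatic carbon

Only compound 1 and compound 2 can anchor an expectation, and neither carries a phenyl at this position. The step of a 3.0-fold lower number from compound 1 to compound 3 (0.48 log units; beyond the scatter) is expected to be a moderate fall in dose, beyond the scatter but well short of the gap between compound 1 and compound 2. For compound 3 in this assay the estimate is 10 mg/kg, with a range from 3 mg/kg to 30 mg/kg.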

Compound 3, minimum effective dose: 0.3 mg/kg
The estimate for compound 3 lay 33-fold (1.52 log units) above the measured number; measured number below the stated range.
By their numbers in this assay, from the lowest: compound 2; then compound 3; then compound 1.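

In this assay, among the compounds shown here, phenyl in place of isobutyl on this aromatic carbon gives a 100-fold lower number from compound 1 to compound 3 (2.00 log units; beyond the scatter) and is the first change that can be read at a single place. The core of compound 1 stays as it is, so this position alone can carry a large shift in minimum effective dose, which the earlier pair of compounds could only hint at. The two groups have the same hydrogen-bond donor and acceptor counts and no net charge, so the step goes with a swap of an open branched group for a six-membered aromatic ring of carbon only, and not with any difference in those counts. Nothing available explains the size of this step.

From the compounds shown here alone, it remains open whether the aromatic ring itself matters or whether a saturated ring such as cyclohexyl would serve equally at this place. Also open, going by these compounds, is how far this position tolerates further substitution, for instance a phenyl carrying an amine or a carboxylic acid, and whether a shorter or longer carbon chain would give a dose on the same scale.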